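Trimming an ethyl to methyl on the ring nitrogen

A few compounds are considered here, and "the series" means these few. Any claim that something is new, unique, unknown or untested is made for them only; others in the source may bear on it.

Of the compounds shown here, three have been measured in a functional assay on Ehrlich cells (Mus musculus) for cytotoxicity, read by trypan blue exclusion, with a stated time of 24 h, tested at 25 uM; a higher number here means a stronger effect of the compound at the concentration tested, a lower number a weaker effect. Compound 1 `CCN1C/C(=C\c2ccc(OC)cc2)C2=NN(C(N)=S)C(c3ccc(OC)cc3)C2C1` gives 31.7%, compound 2 `COc1cc(/C=C2\CCCc3c2nc(N)c(C#N)c3-c2ccc(O)c(OC)c2)ccc1O` gives 60.2%, and compound 3 `CCN1C/C(=C\c2ccc(OC)cc2)C2=NN(c3nc(-c4ccc(Cl)cc4)cs3)C(c3ccc(OC)cc3)C2C1` gives 98.3%. Among the measured compounds shown here, compound 3 thus stands highest of the three, beyond the scatter from both others; the single measured step, a number 66.6 percentage points higher from compound 1 to compound 3 (beyond the scatter), shows a large rise that comes with the larger group on the amine nitrogen in the ring.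

Compound 4 `COc1ccc(/C=C2\CN(C)CC3C2=NN(c2nc(-c4ccc(Cl)cc4)cs2)C3c2ccc(OC)cc2)cc1` differs from compound 3 in one place: hydrogen in place of methyl on a saturated chain carbon bound to an amine nitrogen in a ring. For the measured compounds named here, no measured step touches this position, since the only step concerns the group on the ring nitrogen, so nothing measured bears directly on it. With one carbon leaving and nothing but hydrogen entering, a step within the scatter is the plain expectation in this assay, and a small downward drift is allowed for. Compound 4 is therefore expected to give 92%, within 75% to 100%, which means an expected step of a number 6.3 percentage points lower from compound 3 to compound 4 (within the scatter).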

Compound 4, a percentage reported as activity, at one concentration (the size of the read-out at that concentration, not a potency): 29.2%
The estimate for compound 4 lay 62.8 percentage points above the measured number; measured number outside the range, below it.
By their numbers in this assay, from the lowest: compounds 4 and 1 (each within the scatter of the next); then compound 2; then compound 3.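

Among the compounds shown here, compound 3 depends on the ethyl on its ring nitrogen far more than the earlier compounds could show: in this assay, the change from ethyl to methyl gives a number 69.1 percentage points lower from compound 3 to compound 4 (beyond the scatter), a large step from the loss of one carbon. For the compounds shown here, until now, the only measured step was the exchange of the larger group that separates compound 1 from compound 3, so the high reading could be tied to that group alone; it now also rests on this one carbon. Nothing shown here explains why so small a change has so large an effect.

As far as these compounds go, whether a propyl or a benzyl group in this place would keep the reading of compound 3 remains open. So does whether the change from ethyl to methyl would act in the same way on compound 1.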